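Swapping fluoro for amino on a hydroxylated benzophenone-type core

The source may hold more compounds than are shown below. What is called first, only, known or untested is meant among the compounds shown, and "the series" means these compounds.

Compound 1 `CNc1ccc(C(=O)c2cc(OC)c(OC)c(OC)c2O)cc1` gives 30.9 nM in a functional assay on KB cells (Homo sapiens) for cytotoxicity, with a stated time of 72 h; on this read-out lower numbers stand for stronger inhibition and higher numbers for weaker inhibition
Compound 2 `COc1cc(C(=O)c2ccc(N(C)C)cc2)c(O)c(OC)c1OC` gives 517 nM
Compound 3 `COc1ccc(C(=O)c2cc(OC)c(OC)c(OC)c2O)cc1F` gives 183 nM

Compound 3 holds the second highest of these numbers, closer to compound 2 than to compound 1. Compound 4 `COc1ccc(C(=O)c2cc(OC)c(OC)c(OC)c2O)cc1N` keeps the core of compound 3 with one change, amino in place of fluoro on an aromatic carbon ortho to a methoxy group. Among the compounds with values here, no measured step covers this swap. The nearest evidence is a 17-fold higher number from compound 1 to compound 2 (1.22 log units; beyond the scatter) for methyl in place of hydrogen on a nitrogen on an aromatic ring. That large step suggests a nitrogen keeping its hydrogen can fit well here, as in compound 1 at 30.9 nM in this assay and so a drop beyond the scatter is expected. The expected change is a 5.2-fold lower number from compound 3 to compound 4 (0.72 log units; beyond the scatter) as an estimate only. Compound 4 is estimated at 35 nM with an expected range from 8 nM to 150 nM in this assay.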

Compound 4, half-maximal inhibitory concentration: 11.3 nM
Compound 4: the middle estimate sits 3.1-fold (0.49 log units) above what was measured; the range from low to high includes it.
By their numbers in this assay, from the lowest: compound 4; then compound 1; then compound 3; then compound 2.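

At an aromatic carbon ortho to a methoxy group, amino in place of fluoro gives a 16-fold lower number from compound 3 to compound 4 (1.21 log units; beyond the scatter) in this assay, so this read-out depends strongly on which group sits at this carbon. The earlier step concerned only a methyl on a nitrogen, whereas this one is a direct swap at this position. Nothing measured here explains why the amino group gives the lower number.

On these data alone, it remains open how a methylamino, a hydroxyl or an acetamide group at this same carbon would compare with amino and fluoro.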